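The source may hold more compounds than are shown below. What is called first, only, known or untested is meant among the compounds shown, and "the series" means these compounds.

Two protected nucleoside-like compounds, each carrying a nitrile on the sugar ring, have been examined in an ADME assay on HeLa cells (Homo sapiens) for cytotoxicity; a higher number here means that more compound is tolerated, a lower number that less compound is tolerated. Compound 1 `CC(=O)Nc1ccn(C2OC(CO[Si](C)(C)C(C)(C)C)C(C#N)C2O[Si](C)(C)C(C)(C)C)c(=O)n1` bears an acetyl on a nitrogen of its base. In this assay compound 1 gives > 4 ug/mL, which is a limit of the assay rather than a number. Compound 2 `CC(C)(C)[Si](C)(C)OC[C@H]1O[C@@H](n2cnc3c(N)ncnc32)[C@H](O[Si](C)(C)C(C)(C)C)[C@H]1C#N` carries a different base on the same protected sugar. For compound 2 this assay also reports only a limit, > 100 ug/mL. Within the data shown here, with compound 1 sitting at the limit of > 4 ug/mL in this assay, at which 1 of the 2 values shown sits, and compound 2 at the limit of > 100 ug/mL in this assay, at which 1 of the 2 values shown sits, neither result pins down a true cytotoxic concentration, and no step between the two can be sized. Compound 3 `CC(C)(C)[Si](C)(C)OCC1OC(n2ccc(N)nc2=O)C(O[Si](C)(C)C(C)(C)C)C1C#N` follows from compound 1 by a single change, (hydrogen in place of acetyl on a nitrogen on an aromatic ring). Because compound 1 stands at the limit of > 4 ug/mL in this assay, at which 1 of the 2 values shown sits, and compound 2 at the limit of > 100 ug/mL in this assay, at which 1 of the 2 values shown sits, the change is expected to shift tolerance by no more than the usual scatter, and the step that the limit leaves unreadable from compound 1 to compound 3 is what is expected. Compound 3 is therefore estimated at 100 ug/mL, with a range from 20 ug/mL to 300 ug/mL, and most likely the assay will again report only a limit.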

Compound 3, minimum cytotoxic concentration: > 4 ug/mL
Compound 3 ended at the assay's limit; the forecaster's own chance of this, stated with the estimate: 80%; the middle value lies beyond the limit too.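

In this assay compound 3 gives > 4 ug/mL, which is a limit of the assay and not a number. Compound 1 also has only a limit, so no step can be read between compound 1 and compound 3. The compounds shown leave open the concentration at which any of them harms the cells, and whether changing acetamido to amino shifts it.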